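A few compounds are considered here, and "the series" means these few. Any claim that something is new, unique, unknown or untested is made for them only; others in the source may bear on it.

Measured compounds:
compound 1 `Nc1nc(O)c2c(n1)n(C1OC(CO)[C@@H](O)[C@H]1O)c(=O)n2C/C=C/c1ccccc1`, 73%
compound 2 `C=CCn1c(=O)n(Cc2ccccc2)c2nc(N)nc(O)c21`, 25%

In a functional assay on the whole organism (B cells) with Mus musculus as the target (a higher number here means a larger maximal response, a lower number a smaller maximal response), compound 1 gives 73%, the highest of the two numbers. Compound 2 gives 25%, a gap beyond the scatter. The two compounds differ in more than one place, so no single step can be read from them. Compound 3 `Nc1nc(O)c2c(n1)n(C1OC(CO)[C@@H](O)[C@H]1O)c(=O)n2CCN1CCCCC1` differs from compound 1 by (piperidin-1-yl)methyl in place of 2-phenylethenyl on a saturated chain carbon bound to an aromatic nitrogen. For the measured compounds named here, no measured pair shows what this change does here, so the expectation rests on compound 1 alone. A moderate decrease in maximal response is expected: a number 23 percentage points lower from compound 1 to compound 3 (beyond the scatter). Compound 3 is therefore estimated at 50%, in a range from 25% to 75%.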

Compound 3, largest response reached (reported as maximal response), in percent of the reference or control that the assay uses: 0%
Estimate against measurement, compound 3: 50 percentage points above; the measured number lies below the stated range.
By their numbers in this assay, from the lowest: compound 3; then compound 2; then compound 1.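

On the saturated chain carbon bound to an aromatic nitrogen, the group decides whether the core of compound 1 gives any response at all in this assay. Putting (piperidin-1-yl)methyl in place of 2-phenylethenyl gives a number 73 percentage points lower from compound 1 to compound 3 (beyond the scatter) and leaves compound 3 at 0%. No measurement at hand accounts for this step. The compounds shown do not separate the loss of the six-membered aromatic ring from the entry of the ring nitrogen. A cyclohexylmethyl or benzyl group at this place would leave that question open no longer.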